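This account rests on a few compounds, and the source may have more. Where it says the series, first, only, none or still open, it means among the compounds named here.

Among the measured compounds shown here, in an ADME assay on KB cells (Homo sapiens) for cytotoxicity, with a stated time of 48 h (on this read-out higher numbers stand for weaker inhibition and lower numbers for stronger inhibition), compound 1 `C=C1[C@H](C)CCC[C@]1(C)CC/C(C)=C/CC1=C(O)C(=O)C=C(N[C@@H](C(=O)O)C(C)C)C1=O` gives 6.2 ug/mL, the only exact number so far. For compound 2 `CC1=CCC[C@](C)(CC/C(C)=C/CC2=C(O)C(=O)C=C(N[C@@H](CO)C(=O)O)C2=O)[C@@H]1C`, the same assay returns only a limit, > 10 ug/mL. Compound 3 `C=C1[C@H](C)CCC[C@]1(C)CC/C(C)=C/CC1=C(O)C(=O)C=C(OC)C1=O` keeps the core of compound 1 and differs from it in one place, methoxy in place of (1-carboxy-2-methylpropyl)amino on a double-bonded ring carbon. For the measured compounds named here, no measured pair of compounds isolates this change, so the forecast for this assay is anchored only on compound 1 at 6.2 ug/mL. A small shift toward stronger inhibition is expected, but one that stays within the usual scatter of the measurement. The expected change is a 1.4-fold lower number from compound 1 to compound 3 (0.14 log units; within the scatter). For compound 3 the estimated value is 4.5 ug/mL, with an expected range from 1.3 ug/mL to 14 ug/mL.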

Compound 3, half-maximal inhibitory concentration: > 10 ug/mL
Compound 3: a limit, no number; the forecaster's own chance of this, stated with the estimate: 20%; at least 2.2-fold (0.34 log units) between middle value and limit.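

Swapping (1-carboxy-2-methylpropyl)amino for methoxy on the double-bonded ring carbon gives the first single-place comparison at this position in this assay, and it reads as an at least 1.6-fold higher number from compound 1 to compound 3 (0.20 log units; that floor lies within the scatter). With methoxy at this ring carbon, compound 3 no longer gives an exact number, whereas compound 1 gives 6.2 ug/mL. The floor of this step does not establish a real loss of activity. The size of the step stays unknown, because the read-out stops at a limit: the limit of > 10 ug/mL in this assay, at which 2 of the 3 values shown sit.

The compounds shown do not separate the roles of the nitrogen link and the carboxylic acid in the departing group. From the compounds shown here alone, it also remains open whether a simple amine, or an amino group bearing a shorter or longer chain without the acid, would give an exact number at this ring carbon.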